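The compounds below may be only part of what the source reports. "The series", "measured", "known", "first", "only" and "open" are said of these compounds alone.

Two compounds share one core and differ only in the group on one aromatic carbon. Compound 1 `CC(=O)/C(=N\c1cccc(C)c1)NNc1ccccc1C` carries a methyl there, and in an assay on isolated protein for binding affinity to corticotropin-releasing factor receptor 1 (Homo sapiens) (a lower number here means a stronger inhibitor, a higher number a weaker inhibitor), compound 1 gives 526 nM. Compound 2 `CC(=O)/C(=N\c1cccc(C)c1)NNc1ccccc1C(F)(F)F` carries a trifluoromethyl instead, and in this assay compound 2 gives 1420 nM, the highest of the two numbers, with the step of a 2.7-fold higher number from compound 1 to compound 2 (0.43 log units; beyond the scatter) lying beyond the scatter. Compound 3 `CC(=O)/C(=N\c1cccc(C)c1)NNc1ccccc1` has not yet been measured and differs from compound 2 by hydrogen in place of trifluoromethyl on an aromatic carbon. Within the data shown here, the only measured step that bears on this change is a 2.7-fold higher number from compound 1 to compound 2 (0.43 log units; beyond the scatter), in which the trifluoromethyl arrived and the number rose, so its removal is expected to bring the number back down by a comparable amount. For compound 3 the step is estimated as a 2.4-fold lower number from compound 2 to compound 3 (0.37 log units; beyond the scatter). Compound 3 is therefore expected to give about 600 nM in this assay, within a range of 250 nM to 1500 nM.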

Compound 3, inhibition constant: 4710 nM
Compound 3: middle estimate off by 7.9-fold (0.89 log units), on the low side; the whole stated range lies below it.
By their numbers in this assay, from the lowest: compound 1; then compound 2; then compound 3.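

Hydrogen on this aromatic carbon gives the weakest binding of the three groups in this assay, with a 3.3-fold higher number from compound 2 to compound 3 (0.52 log units; beyond the scatter) on losing the trifluoromethyl and a 9.0-fold higher number from compound 1 to compound 3 (0.95 log units; beyond the scatter) on losing the methyl. The trifluoromethyl, which looked like a loss when set against methyl, is therefore a gain when set against hydrogen, and both substituted compounds stand on the same side of hydrogen, which the first pair alone could not show. Nothing available explains this order of methyl, then trifluoromethyl, then hydrogen.

Three groups on one carbon cannot tell whether a chlorine, a methoxy or an ethyl there would give a lower number than the methyl of compound 1. As far as these compounds go, whether the same order holds when the other aromatic methyl of the shared core is replaced also remains open.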